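Thiourea aryl swap on the shared core, compound 4

This account rests on a few compounds, and the source may have more. Where it says the series, first, only, none or still open, it means among the compounds named here.

Three thioureas sharing the core of compound 1 `CNC(=O)c1ccc(Oc2cccc(NC(=S)Nc3cc(C(F)(F)F)cc(C(F)(F)F)c3)c2)nc1` have been measured in a functional assay on PC-3 cells (Homo sapiens) for antiproliferative activity, read by MTT assay; a lower number here means a stronger inhibitor, a higher number a weaker inhibitor. Compound 1 gives 5860 nM. Compound 2 `CNC(=O)c1ccc(Oc2cccc(NC(=S)Nc3ccc(Cl)cc3Cl)c2)nc1` gives 19300 nM, the second highest of the three numbers; its nearest neighbour is compound 3 `CNC(=O)c1ccc(Oc2cccc(NC(=S)Nc3ccc(F)c(F)c3)c2)nc1`, which gives 23100 nM, and the two lie within the scatter of each other, while compound 1 stands beyond the scatter on the lower side. Within the data shown here, the only step between measured compounds that differ in one place is a 1.2-fold higher number from compound 2 to compound 3 (0.08 log units; within the scatter), an exchange of one halogenated aryl for another on the thiourea nitrogen.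

Compound 4 `CNC(=O)c1ccc(Oc2cccc(NC(=S)Nc3ccc(C)cc3)c2)nc1` has not yet been measured. It differs from compound 2 by 4-methylphenyl in place of 2,4-dichlorophenyl on an amide-type nitrogen. Among the measured compounds shown here, the change again touches the aryl on the amide-type nitrogen next to the thiocarbonyl carbon, the same place the measured step probes, but no measured pair covers a 4-methylphenyl. For the measured compounds named here, the one step at that position stayed within the scatter, and the lower number of compound 1 with bis(trifluoromethyl)phenyl is the only hint that the aryl matters at all. The expected step is therefore small, a 1.3-fold higher number from compound 2 to compound 4 (0.11 log units; within the scatter), with a slight lean toward a higher number. Compound 4 is estimated at 25000 nM, in the range 8000 nM to 70000 nM.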

Compound 4, half-maximal inhibitory concentration: > 100000 nM
Compound 4 ended at the assay's limit; the forecaster's own chance of this, stated with the estimate: 15%; middle value at least 4.0-fold (0.60 log units) from the limit.
By their numbers in this assay, from the lowest: compound 1; then compounds 2 and 3 (each within the scatter of the next). At a limit, above all of these: compound 4.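

Compound 4 reads only as a limit of the assay, not as a number: the limit of > 100000 nM in this assay, at which 1 of the 4 values shown sits.

Among these compounds, this shows that the aryl on the amide-type nitrogen is not indifferent to exchange, as the single earlier step, a 1.2-fold higher number from compound 2 to compound 3 (0.08 log units; within the scatter), might have suggested. In this assay, 4-methylphenyl in place of 2,4-dichlorophenyl gives an at least 5.1-fold higher number from compound 2 to compound 4 (0.71 log units; beyond the scatter), and 4-methylphenyl in place of 3,4-difluorophenyl gives an at least 4.3-fold higher number from compound 3 to compound 4 (0.63 log units; beyond the scatter), so both steps lie beyond the scatter and both give only a lower bound on their size. Among the four compounds shown, the three aryls bearing chlorine, fluorine or trifluoromethyl all give a measurable number, and the one aryl with carbon only as its substituent atom does not, a pattern that rests on this single compound.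

The exchange removes two chlorines and adds a methyl in one step, so the compounds shown cannot separate the loss of halogen from the gain of methyl. A plain phenyl, or a phenyl carrying a single chlorine, would be needed to tell these two apart at this position.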